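The source may report more compounds than this note shows. Statements on the series, on what has been measured and on what is new or still open speak of the compounds shown alone.

In an ADME assay on HeLa cells (Homo sapiens) for cytotoxicity, read by XTT assay (on this read-out higher numbers stand for lower toxicity in this test and lower numbers for higher toxicity in this test), compound 1 (`C1=C(CCCCc2ccccc2)COc2ccccc21`) gives 100000 nM and compound 2 (`c1ccc(CCC2COc3ccccc3C2)cc1`) gives 6250 nM. Compound 3 (`c1ccc(CCCC2COc3ccccc3C2)cc1`) gives 200000 nM, which lies within the usual scatter of compound 1, while compound 2 sits lower, beyond that scatter. Compound 4 (`Clc1ccc2c(c1)CC(CCCc1ccccc1)CO2`) departs from compound 3 in one place: chloro in place of hydrogen on an aromatic carbon. Within the data shown here, no measured pair shows what this change does in this assay, so the expectation is tentative: a moderate fall in the number, not far beyond the scatter. The expected move is a 2.5-fold lower number from compound 3 to compound 4 (0.40 log units; beyond the scatter). Compound 4 is estimated at 80000 nM, with an expected range from 20000 nM to 250000 nM.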

Compound 4, half-maximal cytotoxic concentration: 200000 nM
For compound 4 the middle estimate is 2.5-fold (0.40 log units) below the measured one; low and high end bracket the measured number.
By their numbers in this assay, from the lowest: compound 2; then compounds 1, 3 and 4 (each within the scatter of the next).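

In this assay, chloro in place of hydrogen on an aromatic carbon gives no change at the digits printed from compound 3 to compound 4 (within the scatter). Among these compounds, this is the first step that differs in one place, and it shows that, on the core of compound 3, chloro at this carbon, meta to a fused ring and para to a fused ring, leaves the number where it was. Nothing measured here offers an explanation for this result.

On these data alone, whether fluoro, methoxy or an amine at this same carbon would also leave the number in place remains open. So does whether chloro would do the same on compound 2, which gives 6250 nM.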